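Removing one fluoro from compound 2

The source may report more compounds than this note shows. Statements on the series, on what has been measured and on what is new or still open speak of the compounds shown alone.

Compound 2 `CCn1c(=O)/c(=C2\Sc3ccccc3N2C)s/c1=C\c1ccncc1Nc1cc(F)ccc1F` stands highest of the two numbers measured in a functional assay on MCF7 cells (Homo sapiens) for inhibition (a lower number here means a stronger inhibitor, a higher number a weaker inhibitor), where compound 2 gives 1500 nM. Compound 1 `CCn1c(=O)/c(=C2\Sc3ccc(C)cc3N2C)s/c1=C\c1ccncc1Nc1ccccc1F` gives 100 nM in this assay. Compound 3 `CCn1c(=O)/c(=C2\Sc3ccccc3N2C)s/c1=C\c1ccncc1Nc1ccccc1F` has not yet been measured. It differs from compound 2 by hydrogen in place of fluoro on an aromatic carbon. Compound 1 also carries a 2-fluorophenyl group and shows the lower number, so a moderate improvement is expected; compound 3 is estimated to give 450 nM, within 130 nM to 1500 nM. The expected step is a 3.3-fold lower number from compound 2 to compound 3 (0.52 log units; beyond the scatter).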

Compound 3, half-maximal inhibitory concentration: 330 nM
Compound 3: the middle estimate sits 1.4-fold (0.13 log units) above what was measured; the range from low to high includes it.
By their numbers in this assay, from the lowest: compound 1; then compound 3; then compound 2.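

In this assay, replacing the fluoro para to the other fluoro with hydrogen, which turns 2,5-difluorophenyl into 2-fluorophenyl, gives a 4.5-fold lower number from compound 2 to compound 3 (0.66 log units; beyond the scatter), so this aromatic carbon fares better with hydrogen than with fluoro. With the 2-fluorophenyl group held constant, hydrogen in place of methyl on the core gives a 3.3-fold higher number from compound 1 to compound 3 (0.52 log units; beyond the scatter), so that second place also moves the number beyond the scatter. Nothing available explains either step. The compounds shown leave open how a chloro, methoxy or amine group at the fluoro's place would compare with hydrogen. They also leave open whether the methyl step holds alongside the 2,5-difluorophenyl group.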